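This account rests on a few compounds, and the source may have more. Where it says the series, first, only, none or still open, it means among the compounds named here.

Three compounds have been measured in a functional assay on HEK293 cells for positive allosteric modulation of metabotropic glutamate receptor 5 (Homo sapiens), read by FLIPR and calcium flux; on this read-out lower numbers stand for an effect already at smaller amounts and higher numbers for an effect only at larger amounts of compound:

compound 1, `O=C(COCc1ccccc1)N1CCN(c2ccc(Cl)cc2Cl)CC1`, giving 1000 nM
compound 2, `O=C(COCc1cccnc1)N1CCN(c2ccc(Cl)cc2Cl)CC1`, giving 1090 nM
compound 3, `O=C(COCc1nccs1)N1CCN(c2ccc(Cl)cc2Cl)CC1`, giving 10300 nM

Compound 3 stands highest of the three. The step of a 10-fold higher number from compound 1 to compound 3 (1.01 log units; beyond the scatter) and the step of a 9.4-fold higher number from compound 2 to compound 3 (0.98 log units; beyond the scatter) both set it apart, while the step of a 1.1-fold higher number from compound 1 to compound 2 (0.04 log units; within the scatter) shows that compound 1 and compound 2 cannot be told apart on this read-out.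

Compound 4, `O=C(CSCc1ccccc1)N1CCN(c2ccc(Cl)cc2Cl)CC1`, has not been measured. It differs from compound 3 by benzylsulfanyl in place of (1,3-thiazol-2-yl)methoxy on a saturated chain carbon bound to a carbonyl carbon. Two parts of this change can be judged separately. Returning from the thiazolyl ring to a phenyl ring reverses the step of a 10-fold higher number from compound 1 to compound 3 (1.01 log units; beyond the scatter), which was large, so a fall of about that size is expected on that account. Among the compounds with values here, the exchange of the ether oxygen for sulfur has no counterpart among the measured compounds, so nothing is known about its effect, and it widens the range.

Taken together, compound 4 is expected to return close to the level of compound 1, so in this assay compound 4 is estimated at 1500 nM, between 400 nM and 6000 nM. This corresponds to an expected step of a 6.9-fold lower number from compound 3 to compound 4 (0.84 log units; beyond the scatter).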

Compound 4, half-maximal effective concentration: 7100 nM
Compound 4: middle estimate off by 4.7-fold (0.68 log units), on the low side; measured number above the stated range.
By their numbers in this assay, from the lowest: compounds 1 and 2 (each within the scatter of the next); then compounds 4 and 3 (each within the scatter of the next).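

In this assay, benzylsulfanyl in place of benzyloxy on the saturated chain carbon bound to a carbonyl carbon gives a 7.1-fold higher number from compound 1 to compound 4 (0.85 log units; beyond the scatter), which shows that this position responds to the linking atom as well as to the ring, since sulfur for the ether oxygen alone, with the phenyl ring kept, carries the number beyond the scatter. The same holds against the pyridine analogue, with a 6.5-fold higher number from compound 2 to compound 4 (0.81 log units; beyond the scatter), while a 1.5-fold lower number from compound 3 to compound 4 (0.16 log units; within the scatter) places compound 4 level with compound 3, so a phenyl ring does not by itself secure the level of compound 1, and two different changes, one to the ring and one to the linking atom, end at numbers that cannot be told apart. Nothing available here accounts for the effect of the sulfur.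

From the compounds shown here alone, what remains open is whether sulfur acts the same way with a pyridin-3-yl or a 1,3-thiazol-2-yl ring, or whether the two changes would add up in one compound. Also open, going by these compounds, is how this position would answer to a nitrogen, a plain methylene or a sulfone as the link, or to a longer chain.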